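Working notes: changing the ester-side group of the carbamate series

A few compounds are considered here, and "the series" means these few. Any claim that something is new, unique, unknown or untested is made for them only; others in the source may bear on it.

Measured so far in an assay on CHO cells for displacement of a labelled ligand from muscarinic acetylcholine receptor M5 (Homo sapiens), read by scintillation counting, with a stated time of 2 h; a higher number here means a weaker inhibitor, a lower number a stronger inhibitor:
compound 1 `O=C(OCc1ccc(Cl)c(Cl)c1)N(c1ccccc1)C1CN2CCC1CC2` gives 60 nM
compound 2 `COc1ccc(COC(=O)N(c2ccccc2)C2CN3CCC2CC3)cc1F` gives 40 nM

Among the compounds with values here, compound 2 holds the lower of the two numbers in this assay, but its only neighbour is compound 1, and the step of a 1.5-fold lower number from compound 1 to compound 2 (0.18 log units; within the scatter) lies within the scatter, so the two compounds cannot be ranked against each other. That step exchanged one aryl group for another on the saturated chain carbon bound to an oxygen next to a carbonyl group, and it left the number essentially unchanged.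

Compound 3 `O=C(OCCc1ccccc1)N(c1ccccc1)C1CN2CCC1CC2` carries benzyl in place of 3-fluoro-4-methoxyphenyl on a saturated chain carbon bound to an oxygen next to a carbonyl group. Within the data shown here, the one measured step that bears on this position is the step from compound 1 to compound 2, which stayed within the scatter. Since that change at the same place gave a 1.5-fold lower number from compound 1 to compound 2 (0.18 log units; within the scatter), no step beyond the scatter is expected here either, and the estimated step is a 1.5-fold higher number from compound 2 to compound 3 (0.18 log units; within the scatter) in this assay. Compound 3 is therefore estimated at 60 nM, expected to fall between 20 nM and 200 nM.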

Compound 3, inhibition constant: 260 nM
Estimate against measurement, compound 3: 4.3-fold (0.64 log units) below; measured number outside the range, above it.
By their numbers in this assay, from the lowest: compounds 2 and 1 (each within the scatter of the next); then compound 3.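

The position is not indifferent to every exchange: in this assay, benzyl in place of 3-fluoro-4-methoxyphenyl gives a 6.5-fold higher number from compound 2 to compound 3 (0.81 log units; beyond the scatter), and benzyl in place of 3,4-dichlorophenyl gives a 4.3-fold higher number from compound 1 to compound 3 (0.64 log units; beyond the scatter). Both steps lie beyond the scatter, whereas the exchange of one substituted aryl group for the other did not, so compound 3 stands apart from two compounds that cannot themselves be ranked. Nothing available accounts for this separation.

Benzyl differs from both earlier groups in its link to the ring and in the absence of ring substituents, and the three compounds do not separate these two changes. A plain phenyl at this place, a 3-fluoro-4-methoxybenzyl group or a longer chain such as 3-phenylpropyl would bear on that question.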